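This account rests on a few compounds, and the source may have more. Where it says the series, first, only, none or still open, it means among the compounds named here.

Compound 1 `CC[C@H](C)[C@@H]1C(=O)N[C@H](C2Cc3ccccc3C2)C(=O)N1[C@@H](C(=O)N(C)C)c1ccc(C)nc1C` and compound 2 `CC[C@H](C)[C@@H]1C(=O)N[C@H](C2Cc3ccccc3C2)C(=O)N1[C@@H](C(=O)N(C)C)c1cnc(C)cc1C` share one core and differ in a single group. Compound 1 carries 2,6-dimethylpyridin-3-yl on a saturated chain carbon bound to an amide-type nitrogen in a ring and a carbonyl carbon, while compound 2 carries 4,6-dimethylpyridin-3-yl at that place. In an ADME assay on the whole organism (plasma) for pharmacokinetics, with Rattus norvegicus as the target, at a dose of 5 mg/kg by the oral route (on this read-out higher numbers stand for higher exposure at the dose given and lower numbers for lower exposure), compound 1 gives 4730 ng.h/mL and compound 2 gives 2690 ng.h/mL. The measured step is a 1.8-fold lower number from compound 1 to compound 2 (0.25 log units; within the scatter), so compound 2 stands level with compound 1 on these numbers.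

Compound 3 `CC[C@H](C)[C@@H]1C(=O)N[C@H](C2Cc3ccccc3C2)C(=O)N1[C@@H](C(=O)N(C)C)c1cc(C)cnc1C` has not yet been measured. It keeps the core of compound 2 and exchanges only the pyridine group: 2,5-dimethylpyridin-3-yl in place of 4,6-dimethylpyridin-3-yl on a saturated chain carbon bound to an amide-type nitrogen in a ring and a carbonyl carbon. The same atoms are joined differently, with 2,5-dimethylpyridin-3-yl in place of 4,6-dimethylpyridin-3-yl. Within the data shown here, only one measured step bears on this kind of exchange, the one between compound 1 and compound 2, and it stayed within the scatter. Among the measured compounds shown here, no measurement yet shows what 2,5-dimethylpyridin-3-yl does, so this is thin evidence. No step beyond the scatter is therefore expected in this assay, and the estimated step is a 1.3-fold higher number from compound 2 to compound 3 (0.11 log units; within the scatter). For compound 3 the expected value is 3500 ng.h/mL, with an estimated range of 1500 ng.h/mL to 8000 ng.h/mL.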

Compound 3, area under the concentration-time curve: 1370 ng.h/mL
Compound 3: middle estimate off by 2.6-fold (0.41 log units), on the high side; the whole stated range lies above it.
By their numbers in this assay, from the lowest: compounds 3, 2 and 1 (each within the scatter of the next, the first and the last beyond it).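

In this assay the exchange to 2,5-dimethylpyridin-3-yl gives a 2.0-fold lower number from compound 2 to compound 3 (0.29 log units; within the scatter) and also a 3.5-fold lower number from compound 1 to compound 3 (0.54 log units; beyond the scatter) as a modest step, the only one in this set that passes beyond the scatter. Compound 1 and compound 3 carry groups with the same count of heavy atoms, the same single aromatic ring and the same single hydrogen-bond acceptor, so the step shows that how the same atoms are joined in this pyridine group can, on its own, separate two compounds at this place on the saturated chain carbon. Nothing available here accounts for that difference in exposure, and the data give no measured property that could be tied to it.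

What the compounds shown leave open is whether the exposure at this place depends on the two methyl groups themselves, since every pyridine here carries two of them and none carries a methoxy group, a chlorine atom or a single methyl group instead. A plain phenyl ring at the same place would also show whether the ring nitrogen matters to this read-out at all.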